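The compounds below may be only part of what the source reports. "The series", "measured", "known", "first", "only" and "open" are said of these compounds alone.

In a functional assay on OVCAR-3 cells (Homo sapiens) for antiproliferative activity, read by MTT assay, with a stated time of 24 h (on this read-out higher numbers stand for weaker inhibition and lower numbers for stronger inhibition), compound 1 `O=c1[nH]cc(S(=O)(=O)Nc2ccccc2-c2cn(-c3ccc(Cl)cc3)nn2)c(=O)[nH]1` gives 1750 nM and compound 2 `Cc1ccccc1-n1cc(-c2cccc(NS(=O)(=O)c3c[nH]c(=O)[nH]c3=O)c2)nn1` gives 6230 nM. Of these two numbers compound 2 stands at the higher one, and the gap to compound 1 lies beyond the scatter. Compound 3 `O=c1[nH]cc(S(=O)(=O)Nc2cccc(-c3cn(-c4ccc(Cl)cc4)nn3)c2)c(=O)[nH]1` follows from compound 2 by 4-chlorophenyl in place of 2-methylphenyl on an aromatic nitrogen. Among the measured compounds shown here, no measured pair isolates this change; compound 1 carries the same 4-chlorophenyl but differs elsewhere, so its value is only a loose pointer. In this assay the step from compound 2 to compound 3 is expected to be a 2.1-fold lower number from compound 2 to compound 3 (0.32 log units; beyond the scatter), a modest move toward stronger inhibition. Compound 3 is accordingly estimated at 3000 nM, within 1200 nM to 8000 nM.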

Compound 3, half-maximal inhibitory concentration: 2040 nM
Compound 3: middle estimate off by 1.5-fold (0.17 log units), on the high side, within the range that was stated.
By their numbers in this assay, from the lowest: compounds 1 and 3 (each within the scatter of the next); then compound 2.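

In this assay, among the compounds shown here, 4-chlorophenyl in place of 2-methylphenyl on the aromatic nitrogen gives a 3.1-fold lower number from compound 2 to compound 3 (0.48 log units; beyond the scatter) and so provides the first isolated reading of a change at this position. The two groups hold the same count of heavy atoms, so that count does not separate them. Nothing measured here accounts for the step.

The step cannot separate gaining the chlorine from losing the methyl. On these data alone, how a plain phenyl, a 4-methylphenyl or a 2-chlorophenyl would read at this nitrogen stays open.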